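Dropping the 4-fluorophenyl from a biaryl sulfone

A few compounds are considered here, and "the series" means these few. Any claim that something is new, unique, unknown or untested is made for them only; others in the source may bear on it.

Measured so far:
compound 1, `CCCCc1nc(=O)c(S(=O)(=O)c2ccc(-c3ccc(F)cc3)cc2)c(O)n1-c1c(OC)cccc1OC`, 132 nm/s
compound 2, `CCCCc1[nH]c(=O)c(S(=O)(=O)c2ccc(-c3ccncc3C)cc2)c(O)c1-c1c(OC)cccc1OC`, 76 nm/s

In an ADME assay for permeability, using PAMPA, at pH 7.4 (a lower number here means that the compound crosses the layer more slowly, a higher number that the compound crosses the layer faster), compound 1 gives 132 nm/s, the higher of the two numbers recorded. In this assay compound 2 gives 76 nm/s; the two numbers lie within the scatter of each other, so no order between compound 1 and compound 2 can be read from them.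

Compound 3, `CCCCc1nc(=O)c(S(=O)(=O)c2ccccc2)c(O)n1-c1c(OC)cccc1OC`, has not yet been measured in this assay. It differs from compound 1 by hydrogen in place of 4-fluorophenyl on an aromatic carbon. Among the compounds with values here, no step between measured compounds of this kind is available, so the step of a 1.3-fold lower number from compound 1 to compound 3 (0.12 log units; within the scatter) is expected to stay within the scatter, with a slight lean toward a lower number. For compound 3 the expected value in this assay is 100 nm/s, with a range from 40 nm/s to 250 nm/s.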

Compound 3, apparent permeability: 1.5 nm/s
Beside the measured number, compound 3's estimate is 67-fold (1.82 log units) above it; measured number outside the range, below it.
By their numbers in this assay, from the lowest: compound 3; then compounds 2 and 1 (each within the scatter of the next).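

In this assay, putting hydrogen in place of the 4-fluorophenyl, on an aromatic carbon para to a large group, gives an 88-fold lower number from compound 1 to compound 3 (1.94 log units; beyond the scatter), so what sits at this position matters greatly for the read-out. It is the first step beyond the scatter among the compounds shown. Nothing measured here explains its size.

Still open, as far as these compounds go, is whether the whole aromatic ring is needed or only part of it. A plain phenyl, a methoxy group or a butyl chain at this position would help separate these possibilities.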